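Bromo in place of 4-methoxyphenyl in compound 2

This account rests on a few compounds, and the source may have more. Where it says the series, first, only, none or still open, it means among the compounds named here.

Compound 1 `O=C(NCCCCc1ccccc1)n1c(=O)oc2cc(-c3ccc(F)cc3)ccc21`: > 5 h
Compound 2 `COc1ccc(-c2ccc3c(c2)oc(=O)n3C(=O)NCCCCc2ccccc2)cc1`: 2.2 h
Compound 3 `O=C(NCCCCc1ccccc1)n1c(=O)oc2cc(Br)ccc21`: not yet measured

Going by the values given here, in a physicochemical assay for metabolic stability, read by HPLC, in phosphate buffer, at pH 7.4, tested at 10 uM (a lower number here means that the compound disappears faster, a higher number that the compound lasts longer), compound 2 gives 2.2 h, the only exact number so far. Compound 1 stands at a limit, > 5 h.

Compound 3 follows from compound 2 by bromo in place of 4-methoxyphenyl on an aromatic carbon. Among the compounds with values here, the one measured step is an at least 2.2-fold lower number from compound 1 to compound 2 (0.35 log units; beyond the scatter). Within the data shown here, it changed only a substituent on the group that now leaves, so it gives weak guidance, and no measured step removes that group.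

No change beyond the scatter is therefore expected in this assay, and the expected step is a 1.4-fold higher number from compound 2 to compound 3 (0.13 log units; within the scatter). For compound 3 the estimate is 3 h, with an expected range from 1.2 h to 8 h.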

Compound 3, half-life: 0.4 h
Estimate against measurement, compound 3: 7.5-fold (0.88 log units) above; the whole stated range lies above it.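

In this assay, bromo in place of 4-methoxyphenyl gives a 5.5-fold lower number from compound 2 to compound 3 (0.74 log units; beyond the scatter), so this aromatic carbon responds to losing the whole ring and not only to a change of substituent on that ring. Bromo in place of 4-fluorophenyl points the same way, with an at least 12-fold lower number from compound 1 to compound 3 (1.09 log units; beyond the scatter). The value of compound 1, > 5 h, is a limit.

The compounds shown leave open whether an unsubstituted phenyl, a chloro or an amine at this carbon would read closer to compound 2 or to compound 3. They also leave open whether the fall follows the loss of the ring or the arrival of bromo.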